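Trifluoromethoxy for Fluoro: A Step Taken Without Guidance

This account rests on a few compounds, and the source may have more. Where it says the series, first, only, none or still open, it means among the compounds named here.

Measured compounds:
compound 1 `O=C(O)Cn1nnc(-c2cc(OCCOCc3cc(F)ccc3Br)no2)n1`, in an assay on cells (Hepatocyte) for inhibition of acyl-CoA desaturase 1 (Rattus norvegicus) (on this read-out lower numbers stand for stronger inhibition and higher numbers for weaker inhibition), compound 1 gives "not determined" (no result reported)
compound 2 `O=C(O)Cn1nnc(-c2nnc(OCCCOc3cc(F)ccc3Br)s2)n1`, in this assay compound 2 gives "not determined" (no result reported)
compound 3 `O=C(O)Cn1nnc(-c2cnc(OCCCOc3cc(F)ccc3Br)s2)n1`, this assay: 176 nM

Three compounds share the acid-bearing head group, yet only compound 3 carries a number: in this assay compound 3 gives 176 nM, and with compound 1 recorded as "not determined" (no result reported) and compound 2 recorded as "not determined" (no result reported), it stands alone, neither strong nor weak by comparison.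

Compound 4 `O=C(O)Cn1nnc(-c2cnc(OCCCOc3cc(OC(F)(F)F)ccc3Br)s2)n1` differs from compound 3 in one place: trifluoromethoxy in place of fluoro on an aromatic carbon. Among the measured compounds shown here, no pair of measured compounds shows what such a change does, so there is no step to lean on. The expected step from compound 3 to compound 4 is a 1.1-fold higher number from compound 3 to compound 4 (0.06 log units; within the scatter), not beyond the usual scatter in either direction. For compound 4 the expected value is 200 nM, with a range from 70 nM to 600 nM.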

Compound 4, half-maximal inhibitory concentration: 91 nM
Beside the measured number, compound 4's estimate is 2.2-fold (0.34 log units) above it; the range from low to high includes it.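

Trifluoromethoxy can take the place of fluoro on this carbon, para to a bromo group, with no shift beyond the usual scatter: the swap gives a 1.9-fold lower number from compound 3 to compound 4 (0.29 log units; within the scatter), even though 5 heavy atoms enter where 1 leaves. Among the compounds shown here, this is the first reading of any change at this position, since compound 3 previously stood alone. Nothing measured here gives a reason for the result. Going by these compounds, whether a methoxy group or an amine on the same carbon would behave in the same way remains open.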